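The compounds below may be only part of what the source reports. "The series", "measured", "known", "first", "only" and "open" are said of these compounds alone.

Measured so far in a functional assay on NCI-H460 cells (Homo sapiens) for antiproliferative activity, with a stated time of 72 h; on this read-out higher numbers stand for weaker inhibition and lower numbers for stronger inhibition
Compound 1 `Nc1ncnn2c([C@@H]3O[C@H](CO)[C@@H](O)[C@H]3O)cc(-c3ccoc3)c12` gives 1500 nM here
Compound 2 `Nc1ncnn2c([C@@H]3O[C@H](CO)[C@@H](O)[C@H]3O)cc(/C=C/c3ccccc3)c12` gives 3700 nM here

Compound 2 holds the higher of the two numbers, so it is the weaker inhibitor of the pair. The next compound to read is compound 3 `Nc1ncnn2c([C@@H]3O[C@H](CO)[C@@H](O)[C@H]3O)cc(-c3ccccc3Cl)c12` with 2-chlorophenyl in place of 2-phenylethenyl on an aromatic carbon of the five-membered aromatic ring with 1 nitrogen, counted as 2-chlorophenyl in place of 2-phenylethenyl on an aromatic carbon in full. Within the data shown here, only one measured step bears on this, a swap at the same carbon: a 2.5-fold higher number from compound 1 to compound 2 (0.39 log units; beyond the scatter) and it was modest. Going by these compounds, one step sets no trend, so in this assay no step beyond the scatter is expected, and the direction stays open. The expected change is a 1.2-fold lower number from compound 2 to compound 3 (0.09 log units; within the scatter) on this estimate. For compound 3 the estimated value is 3000 nM with an expected range from 800 nM to 11000 nM for now.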

Compound 3, half-maximal inhibitory concentration: > 100000 nM
Compound 3: a limit, no number (the forecaster's own chance of this, stated with the estimate: 15%); middle value at least 33-fold (1.52 log units) from the limit.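

In this assay compound 3 gives a limit, not a number: the limit of > 100000 nM in this assay, at which 1 of the 3 values shown sits.

At this aromatic carbon, two ring bonds from the ring nitrogen, the choice of group can do far more than the earlier swap suggested, which gave a 2.5-fold higher number from compound 1 to compound 2 (0.39 log units; beyond the scatter). Placing 2-chlorophenyl here in place of 2-phenylethenyl gives an at least 27-fold higher number from compound 2 to compound 3 (1.43 log units; beyond the scatter), and placing it in place of furan-3-yl gives an at least 66-fold higher number from compound 1 to compound 3 (1.82 log units; beyond the scatter), so this position does not accept every ring-bearing group equally.

The compounds shown do not separate the effect of the chlorine from that of a phenyl ring bonded directly to the core, and a plain phenyl group would bear on that question. Going by these compounds, how an amine or a longer alkyl chain at this carbon would read also stays open.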